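A few compounds are considered here, and "the series" means these few. Any claim that something is new, unique, unknown or untested is made for them only; others in the source may bear on it.

Measured in a functional assay on HeLa cells (Homo sapiens) for antiproliferative activity, read by MTT assay, with a stated time of 72 h; a lower number here means a stronger inhibitor, a higher number a weaker inhibitor:
Compound 1 `CC(C)N1C(=O)COc2ccc(-c3cccc(NS(=O)(=O)c4ccc(F)cc4)c3)cc21`: 22700 nM
Compound 2 `O=C1COc2ccc(-c3cnc4ccccc4c3)cc2N1C1CCCCC1`: 19700 nM
Compound 3 `O=C1COc2ccc(-c3cnc(Cl)c(NS(=O)(=O)c4ccc(F)cc4)c3)cc2N1c1ccc(Cl)cc1`: > 40000 nM

Compound 1 gives 22700 nM in this assay, and this lies within the scatter of compound 2 at 19700 nM. Among the measured compounds shown here, the two form the only pair of true numbers in the set. Compound 3 reads > 40000 nM, which is a limit of the assay and not a number.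

The next entry is compound 4 `O=C1COc2ccc(-c3cccc(NS(=O)(=O)c4ccc(F)cc4)c3)cc2N1C1CCCCC1`, not yet measured. It differs from compound 1 in one place: cyclohexyl in place of isopropyl on an amide-type nitrogen in a ring. The rest of compound 1 is kept.

For the measured compounds named here, no measured pair in the set differs in one place only, so this change has no direct precedent. Going by the values given here, the only indirect guide is compound 2, which also carries cyclohexyl on that nitrogen and gives 19700 nM. On that basis, no step beyond the scatter is expected in this assay. The expected step is a 1.3-fold lower number from compound 1 to compound 4 (0.10 log units; within the scatter), and its direction remains uncertain.

For compound 4 the estimated value is 18000 nM, with an expected range from 7000 nM to 40000 nM.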

Compound 4, half-maximal inhibitory concentration: 10800 nM
For compound 4 the middle estimate is 1.7-fold (0.22 log units) above the measured one, and the stated range covers the measured number.
By their numbers in this assay, from the lowest: compounds 4, 2 and 1 (each within the scatter of the next, the first and the last beyond it). At a limit, above all of these: compound 3.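

In this assay, among the compounds shown here, this is the first reading of a change at a single place: cyclohexyl in place of isopropyl on the amide-type nitrogen in a ring gives a 2.1-fold lower number from compound 1 to compound 4 (0.32 log units; beyond the scatter), with the rest of compound 1 kept. The earlier compounds shown here could not show whether this nitrogen responds to its substituent at all, and this pair shows that it does, though the step is modest and only just clears the usual scatter. Compound 4 at 10800 nM shows that the six-membered carbon ring is accepted here, but nothing in the data bears on the cause of the step.

One pair cannot show whether the trend follows the size of the group, or whether it holds with a longer chain such as n-butyl, an open-chain amine or a carboxylic acid on this nitrogen, or with the amide hydrogen left in place. Compound 3, at > 40000 nM, is a limit of the assay and not a number.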